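Shifting a Methyl Group on a Cell Growth Inhibitor

A few compounds are considered here, and "the series" means these few. Any claim that something is new, unique, unknown or untested is made for them only; others in the source may bear on it.

Two related compounds have been tested in a functional assay on DU-145 cells (Homo sapiens) for inhibition, read by trypan blue exclusion, with a stated time of 96 h; on this read-out lower numbers stand for stronger inhibition of growth and higher numbers for weaker inhibition of growth. Compound 1 `Cc1ccc(C)c(/C=C(\C(=O)c2ccc(Cl)cc2)S(=O)(=O)Cc2ccc(Cl)cc2)c1` gives 10000 nM in this assay. Compound 2 `Cc1ccc(S(=O)(=O)/C(=C/c2cc(C)cc(C)c2)C(=O)c2ccc(Cl)cc2)cc1` gives 1000 nM in this assay, the lower of the two numbers, and its gap to compound 1 lies beyond the usual scatter, so compound 2 is the stronger inhibitor of growth of the pair.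

Compound 3 `Cc1ccc(S(=O)(=O)/C(=C/c2cc(C)ccc2C)C(=O)c2ccc(Cl)cc2)cc1` has not been measured. It differs from compound 2 in one place: 2,5-dimethylphenyl in place of 3,5-dimethylphenyl on a double-bonded chain carbon bound to a double-bonded chain carbon. Both rings carry two methyl groups; only their position on the ring changes. Among the measured compounds shown here, no measured pair in this set shows what such a shift does, so there is no step to lean on. The expected step from compound 2 to compound 3 is a 1.5-fold higher number from compound 2 to compound 3 (0.18 log units; within the scatter), modest and within the scatter. Compound 3 is estimated to give 1500 nM in this assay, with a range from 500 nM to 5000 nM.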

Compound 3, concentration for 50% growth inhibition: 1000 nM
Estimate against measurement, compound 3: 1.5-fold (0.18 log units) above, and the stated range covers the measured number.
By their numbers in this assay, from the lowest: compounds 2 and 3 (each within the scatter of the next); then compound 1.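

In this assay the change to 2,5-dimethylphenyl from 3,5-dimethylphenyl gives no change at the digits printed from compound 2 to compound 3 (within the scatter) and so, at this place on the chain, the two methyl patterns on the ring cannot be told apart. Among the compounds shown here, on the sulfonyl sulfur, 4-methylphenyl in place of 4-chlorobenzyl gives a 10-fold lower number from compound 1 to compound 3 (1.00 log units; beyond the scatter) and this is the first comparison at that place, since compound 1 and compound 2 differ in more than one place. Nothing at hand explains either result.

Still open, from the compounds shown here alone, is whether the ring at the chain carbon tolerates groups other than methyl, such as methoxy or an amine, as well as these two methyl patterns do. Going by these compounds, it is also open how a plain phenyl or a longer chain on the sulfonyl sulfur would compare with 4-methylphenyl.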